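Sulfonyl substituent swap in a chalcone-type growth-inhibitor series

The source may hold more compounds than are shown below. What is called first, only, known or untested is meant among the compounds shown, and "the series" means these compounds.

Three compounds of this series have been run in a functional assay on DU-145 cells (Homo sapiens) for inhibition, read by trypan blue exclusion, with a stated time of 96 h; a higher number here means a weaker inhibitor of growth, a lower number a stronger inhibitor of growth. Compound 1 `O=C(/C(=C\c1c(O)cc(O)cc1O)S(=O)(=O)c1ccccc1Br)c1ccc(Cl)cc1` gives 50000 nM. Compound 2 `CCOc1ccc(/C=C(\C(=O)c2ccc(Cl)cc2)S(=O)(=O)Cc2ccc(F)cc2)cc1OC` gives 50000 nM. Compound 3 `O=C(/C(=C\c1ccc([N+](=O)[O-])c(O)c1)SCc1ccc(Br)cc1)c1cc(Cl)ccc1O` gives 10000 nM. On these numbers compound 2 stands level with compound 1, the two sharing the highest value of the three, with no change at the digits recorded; compound 3 sits furthest from compound 2, at a lower number that lies beyond the scatter. For the measured compounds named here, no pair among the measured compounds differs in a single place, so no step is recorded between them.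

The next compound, compound 4 `CCOc1ccc(/C=C(\C(=O)c2ccc(Cl)cc2)S(=O)(=O)c2ccc(C)cc2)cc1OC`, is still to be measured in this assay . It is derived from compound 2 by one change: 4-methylphenyl in place of 4-fluorobenzyl on a sulfonyl sulfur. Compound 1, which carries an aryl group on its own sulfonyl sulfur rather than a benzyl one, shares the value of compound 2, so the expected step from compound 2 to compound 4 in this assay is none beyond the scatter, no change at the digits printed from compound 2 to compound 4 (within the scatter). Compound 4 is therefore expected to give about 50000 nM in this assay , in the range 20000 nM to 100000 nM.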

Compound 4, concentration for 50% growth inhibition: 1000 nM
Estimate against measurement, compound 4: 50-fold (1.70 log units) above; measured number outside the range, below it.
By their numbers in this assay, from the lowest: compound 4; then compound 3; then compounds 1 and 2 (each within the scatter of the next).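

In this assay, 4-methylphenyl in place of 4-fluorobenzyl on a sulfonyl sulfur gives a 50-fold lower number from compound 2 to compound 4 (1.70 log units; beyond the scatter), a large step beyond the scatter. For the compounds shown here, with no single-place pair among the earlier compounds, this is the first direct reading of this position, and it shows that the group on the sulfonyl sulfur can by itself shift the growth-inhibition number this far while the rest of compound 2 stays unchanged. No supporting measurement is available to explain the step.

The change alters both the benzyl-versus-phenyl attachment and the ring substituent, fluorine versus methyl, so the compounds shown do not tell which of the two carries the step. A 4-fluorophenyl or a 4-methylbenzyl group on this sulfur would separate them.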